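Replacing Hydroxy with Bromo in Compound 1

A few compounds are considered here, and "the series" means these few. Any claim that something is new, unique, unknown or untested is made for them only; others in the source may bear on it.

Within the data shown here, in a functional assay on MGC-803 cells (Homo sapiens) for cytotoxicity, read by MTT assay, with a stated time of 72 h (a lower number here means a stronger inhibitor, a higher number a weaker inhibitor), compound 1 (`O=C1C(=Cc2ccc(O)cc2)C(=O)N(c2ccc(Cl)cc2)N1c1ccc(Cl)cc1`) gives 19500 nM and holds the lower of the two numbers so far. In this assay compound 2 (`CN(C)c1ccc(C=C2C(=O)N(c3ccc(Cl)cc3)N(c3ccc(Cl)cc3)C2=O)cc1`) gives 80200 nM and holds the higher one. Compound 3 (`O=C1C(=Cc2ccc(Br)cc2)C(=O)N(c2ccc(Cl)cc2)N1c1ccc(Cl)cc1`) carries bromo in place of hydroxy on an aromatic carbon, para to a large group (bromo in place of hydroxy on an aromatic carbon), so that 4-hydroxyphenyl becomes 4-bromophenyl. Among the measured compounds shown here, only one measured step bears on this change: dimethylamino in place of the same hydroxy gave a 4.1-fold higher number from compound 1 to compound 2 (0.61 log units; beyond the scatter) as a modest rise. Bromo is a different entering group, so that step is only a loose guide, and a smaller rise in this assay, perhaps none beyond the scatter, is expected. The expected change is a 1.8-fold higher number from compound 1 to compound 3 (0.25 log units; within the scatter) as an estimate. The estimate for compound 3 is 35000 nM (expected range 12000 nM to 100000 nM).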

Compound 3, half-maximal inhibitory concentration: 16900 nM
Estimate against measurement, compound 3: 2.1-fold (0.32 log units) above; the measured number falls inside the stated range.
By their numbers in this assay, from the lowest: compounds 3 and 1 (each within the scatter of the next); then compound 2.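

In this assay, bromo can stand in place of hydroxy at this place on the aromatic ring with no change beyond the scatter (a 1.2-fold lower number from compound 1 to compound 3 (0.06 log units; within the scatter)), although bromo counts no hydrogen-bond donor or acceptor where hydroxy counts one of each. The rise seen with dimethylamino therefore does not extend to every group entering here, and bromo in place of dimethylamino gives a step beyond the scatter (a 4.7-fold lower number from compound 2 to compound 3 (0.68 log units; beyond the scatter)). No measurement shown gives a reason for this difference between bromo and dimethylamino.

The compounds shown leave open whether fluoro, an amine or a carboxylic acid at this place would stay level with compound 1 and compound 3 or move as dimethylamino does. They also leave open whether bromo and hydroxy remain level when the rest of the core changes.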